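Trimming the benzyl group: from compound 1 to compound 4

This account rests on a few compounds, and the source may have more. Where it says the series, first, only, none or still open, it means among the compounds named here.

Measured compounds:
- compound 1 `COc1ccc(Cn2c(=O)n(C3OC(CO)[C@@H](O)[C@H]3O)c3nc(N)nc(O)c32)cc1`: 44%
- compound 2 `Nc1nc(O)c2c(n1)n(C1OC(CO)[C@@H](O)[C@H]1O)c(=O)n2Cc1ccc(OCc2ccccc2)cc1`: 5%
- compound 3 `C=CCn1c(=[Se])n(C2OC(CO)[C@@H](O)[C@H]2O)c2nc(N)nc(O)c21`: 70%

In a functional assay on the whole organism (B cells) with Mus musculus as the target (on this read-out lower numbers stand for smaller maximal responses and higher numbers for larger maximal responses), compound 1 gives 44%, which places it second highest of the three numbers. Compound 3 gives 70%, a number beyond the scatter above it, and compound 2 gives 5%, a number beyond the scatter below it.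

The unmeasured compound 4 `Cn1c(=O)n(C2OC(CO)[C@@H](O)[C@H]2O)c2nc(N)nc(O)c21` differs from compound 1 in one place: hydrogen in place of 4-methoxyphenyl on a saturated chain carbon bound to an aromatic nitrogen. The shared core stays untouched.

Among the measured compounds shown here, only one measured step touches a single position, and it concerns the same benzyl region: a number 39 percentage points lower from compound 1 to compound 2 (beyond the scatter). There, enlarging the group on the benzyl carried the response strongly downward. Compound 3, with the small allyl chain, shows the largest number of the three, although it also carries selenium in place of oxygen, so no clean step can be read from it.

Taken together, these numbers suggest that a smaller group on the chain carbon bound to the aromatic nitrogen goes with a larger response. For compound 4 the expected step is therefore a number 16 percentage points higher from compound 1 to compound 4 (beyond the scatter), upward and beyond the scatter. The estimated value for compound 4 is 60%, within a range from 35% to 85%.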

Compound 4, largest response reached (reported as maximal response), in percent of the reference or control that the assay uses: 99%
For compound 4 the middle estimate is 39 percentage points below the measured one, outside the stated range (above it).
By their numbers in this assay, from the lowest: compound 2; then compound 1; then compound 3; then compound 4.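

In this assay, cutting 4-methoxybenzyl back to methyl gives a number 55 percentage points higher from compound 1 to compound 4 (beyond the scatter), and this change removes the six-membered aromatic ring altogether. Among the compounds shown here, until now the only clean step at this position was the enlargement that gave a number 39 percentage points lower from compound 1 to compound 2 (beyond the scatter), so it was known only that a larger group went with a lower number; the position now shows a large move upward as well, and the three compounds that differ here only in this group (compound 2, compound 1 and compound 4) rise in order as the group gets smaller, with compound 3 left out of that reading since it also differs by its selenium. Nothing available here accounts for why the response follows the size of this group.

The compounds shown leave open whether the response falls steadily as the group grows or drops only once an aromatic ring enters, a question that an ethyl or propyl chain, or a plain benzyl group, at this position would help to settle. They also leave open what an amine or a carboxylic acid at the end of such a chain would do to the response.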